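The source may report more compounds than this note shows. Statements on the series, on what has been measured and on what is new or still open speak of the compounds shown alone.

Compound 3 (`O=C(CCC1CCN(Cc2ccccc2)CC1)c1ccc2[nH]ccc2c1`) is one of three compounds sharing a ketone-linked piperidine chain. Its companions are compound 1 (`COc1c(C(=O)CCC2CCN(Cc3ccccc3)CC2)cc(Cl)c2[nH]c([Si](C)(C)C)cc12`), for which in an assay for displacement of a labelled ligand from 5-hydroxytryptamine receptor 4 (Homo sapiens), with a stated time of 60 min (on this read-out lower numbers stand for stronger inhibition and higher numbers for weaker inhibition), the result is "not determined" (no result reported), and compound 2 (`COc1c(C(=O)CCC2CCN(CC3CCCCC3)CC2)cc(Cl)c2[nH]ccc12`), which in this assay gives 40.9 nM. In this assay compound 3 gives 169 nM, the higher of the two numbers, a gap beyond the scatter. Compound 4 (`CCCCN1CCC(CCC(=O)c2ccc3[nH]ccc3c2)CC1`) keeps the core of compound 3 and differs only in that (propyl in place of phenyl on a saturated chain carbon bound to an amine nitrogen in a ring). For the measured compounds named here, no measured pair shows this kind of change, so the step is expected to be small, if anything toward a weaker result: the step from compound 3 to compound 4 in this assay is estimated at a 1.5-fold higher number from compound 3 to compound 4 (0.19 log units; within the scatter). Compound 4 is therefore expected to give about 260 nM in this assay, within a range of 70 nM to 1000 nM.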

Compound 4, inhibition constant: 49.6 nM
Compound 4: the middle estimate sits 5.2-fold (0.72 log units) above what was measured; measured number below the stated range.
By their numbers in this assay, from the lowest: compounds 2 and 4 (each within the scatter of the next); then compound 3.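

In this assay, propyl in place of phenyl on a saturated chain carbon bound to an amine nitrogen in a ring brings a 3.4-fold lower number from compound 3 to compound 4 (0.53 log units; beyond the scatter) and shows that an aromatic ring is not needed at this place on this core. Benzyl to butyl, the same difference cut one bond further out, is a change toward a stronger result here. Nothing available explains this gain. From the compounds shown here alone, whether a longer chain or a chain ending in a hydroxyl group would go further remains open. So does whether the same change would hold on the core of compound 2.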